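Hydroxycarbamoyl chain series: the step to compound 4

A few compounds are considered here, and "the series" means these few. Any claim that something is new, unique, unknown or untested is made for them only; others in the source may bear on it.

Measured so far in a functional assay on U-937 cells (Homo sapiens) for inhibition, read by MTT assay, with a stated time of 48 h (a lower number here means a stronger inhibitor, a higher number a weaker inhibitor), for this series:
- compound 1 `O=C(CCCCOC(=O)c1ccc2c(c1)no[n+]2[O-])NO` gives 19900 nM
- compound 2 `O=C(CCCCCOC(=O)c1ccc2c(c1)no[n+]2[O-])NO` gives 33400 nM
- compound 3 `O=C(CCCCCCOC(=O)c1ccc2c(c1)no[n+]2[O-])NO` gives 12400 nM

Compound 3 separates from only one of the other two numbers. One gap passes the scatter (a 2.7-fold lower number from compound 2 to compound 3 (0.43 log units; beyond the scatter)) and the other does not (a 1.6-fold lower number from compound 1 to compound 3 (0.21 log units; within the scatter)).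

Compound 4 `O=C(CCCCCCCOC(=O)c1ccc2c(c1)no[n+]2[O-])NO` is next, and its difference from compound 3 is counted here ((hydroxycarbamoyl)methyl in place of hydroxycarbamoyl on a saturated chain carbon, six bonds along the chain from an oxygen next to a carbonyl group). It carries (hydroxycarbamoyl)methyl in place of hydroxycarbamoyl on a saturated chain carbon, six bonds along the chain from an oxygen next to a carbonyl group.

The same replacement has been measured twice, four bonds along the chain (a 1.7-fold higher number from compound 1 to compound 2 (0.22 log units; within the scatter)) and five bonds along it (a 2.7-fold lower number from compound 2 to compound 3 (0.43 log units; beyond the scatter)). These two steps run in opposite directions, so the three compounds show no steady trend, and compound 2 goes against any steady fall. Neither direction can be carried forward, and no step beyond the scatter is expected in this assay for the new replacement.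

The estimated step is small (a 1.0-fold higher number from compound 3 to compound 4 (0.02 log units; within the scatter)).

Compound 4 is expected at 13000 nM with an estimated range from 5500 nM to 30000 nM in this measurement.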

Compound 4, half-maximal inhibitory concentration: 11900 nM
For compound 4 the middle estimate is 1.1-fold (0.04 log units) above the measured one, within the range that was stated.
By their numbers in this assay, from the lowest: compounds 4, 3, 1 and 2 (each within the scatter of the next, the first and the last beyond it).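

In this assay, the replacement six bonds along the chain gives no step beyond the scatter (a 1.0-fold lower number from compound 3 to compound 4 (0.02 log units; within the scatter)), so the fall seen at five bonds is not extended, and the change reads the same at four and six bonds: the same change on two cores in this assay, a 1.7-fold higher number (0.22 log units; within the scatter) from compound 1 to compound 2 and a 1.0-fold lower number (0.02 log units; within the scatter) from compound 3 to compound 4, 1.7-fold (0.24 log units) apart, within the scatter of two such steps. Compound 2 now differs beyond the scatter from two chain homologues, compound 3 and compound 4 (a 2.8-fold lower number from compound 2 to compound 4 (0.45 log units; beyond the scatter)), yet not from compound 1, while the three-carbon extension at the four-bond position leaves no step beyond the scatter (a 1.7-fold lower number from compound 1 to compound 4 (0.22 log units; within the scatter)). Among the compounds shown here, the two-carbon extension also agrees across its two starting points, even though only one of the two steps passes the scatter, so compound 2 is a modest departure from an otherwise flat set rather than the start of a trend: the same change on two cores in this assay, a 1.6-fold lower number (0.21 log units; within the scatter) from compound 1 to compound 3 and a 2.8-fold lower number (0.45 log units; beyond the scatter) from compound 2 to compound 4, 1.7-fold (0.24 log units) apart, within the scatter of two such steps.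

Going by these compounds, whether a longer chain than that of compound 4 keeps the numbers level remains open. On these data alone, it is also open how far the numbers depend on the hydroxycarbamoyl end at all, which a carboxylic acid in its place on the same chain and shared core would test.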